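Lipoyl-triazole coumarin ethers: cytotoxicity on PC-12 cells

This account rests on a few compounds, and the source may have more. Where it says the series, first, only, none or still open, it means among the compounds named here.

Working notes on a small set of coumarin ethers carrying a lipoyl amide through a triazole linker, all read in a functional assay on PC-12 cells (Rattus norvegicus) for cytotoxicity, read by MTT assay, with stated times of 3 h and 2 h, tested at 5 uM; a higher number here means a stronger effect of the compound at the concentration tested, a lower number a weaker effect. Compound 1 `Cc1cc(=O)oc2cc(OCCCn3cc(CNC(=O)CCCCC4CCSS4)nn3)ccc12` gives 64.6% in this assay. Compound 2 `O=C(CCCCC1CCSS1)NCc1cn(CCCOc2ccc3cc(-c4ccc(Br)cc4)c(=O)oc3c2)nn1` gives 57.3% in this assay. Compound 3 `O=C(CCCCC1CCSS1)NCc1cn(CCCCOc2ccc3ccc(=O)oc3c2)nn1` gives 52.8% in this assay, the lowest of the three numbers, with compound 2 within the scatter of it and compound 1 beyond it. No two of the measured compounds differ in a single place, so no isolated step can be read from them.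

Compound 4 `COc1ccc(-c2cc3ccc(OCCCCn4cc(CNC(=O)CCCCC5CCSS5)nn4)cc3oc2=O)cc1` is the next member. Against compound 3 the change is 4-methoxyphenyl in place of hydrogen on an aromatic carbon. Nothing measured here fixes the size of such a change on its own, and the three numbers in hand sit close together. Compound 4 is therefore expected to show a step of a number 4.2 percentage points higher from compound 3 to compound 4 (within the scatter), not beyond the scatter, in this assay. The estimate for compound 4 is 57%, with a range from 45% to 70%.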

Compound 4, a percentage reported as activity, at one concentration (the size of the read-out at that concentration, not a potency): 44.9%
Compound 4: the middle estimate sits 12.1 percentage points above what was measured; measured number below the stated range.
By their numbers in this assay, from the lowest: compounds 4, 3, 2 and 1 (each within the scatter of the next, the first and the last beyond it).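

For the compounds shown here, this is the first single-place step: 4-methoxyphenyl in place of hydrogen, on the aromatic carbon two atoms from the ring oxygen, gives a number 7.9 percentage points lower from compound 3 to compound 4 (within the scatter) in this assay. Going by these compounds alone, this position therefore accepts a whole aromatic ring carrying a methoxy group with no step beyond the usual scatter, so the single step does not separate the two compounds in this read-out. No measurement available here accounts for the size or direction of this step.

Still open, from the compounds shown here alone, is how this carbon responds to other groups, such as a carboxylic acid or an amine on the phenyl ring, or a plain methyl. Going by these compounds, it is also open whether the same replacement gives a similar step when the chain linking the triazole to the core is longer or shorter.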